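The source may hold more compounds than are shown below. What is called first, only, known or untested is meant among the compounds shown, and "the series" means these compounds.

Values in a functional assay on HCT-116 cells (Homo sapiens) for inhibition, read by sulforhodamine B assay, with a stated time of 3 days (on this read-out lower numbers stand for stronger inhibition of growth and higher numbers for weaker inhibition of growth), are as follows.

Compound 1 `O=C(/C=C/c1ccccc1Cl)c1ccc(OCc2ccccc2)cc1`: 14900 nM
Compound 2 `O=C(/C=C/c1cccc([N+](=O)[O-])c1)c1ccccc1`: 4470 nM
Compound 3 `O=C(/C=C/c1ccc(OCc2ccccc2)cc1)c1ccccc1`: > 50000 nM

Compound 1 holds the higher of the two actual numbers, and compound 2 lies lower, with a gap beyond the usual scatter. Compound 3 gives no number, only the limit of the assay, > 50000 nM.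

The unmeasured compound 4 `O=C(/C=C/c1ccccc1)c1ccc(OCc2ccccc2)cc1` differs from compound 1 in one place: hydrogen in place of chloro on an aromatic carbon. Hydrogen stands in place of chloro on an aromatic carbon, so 2-chlorophenyl becomes phenyl.

Going by the values given here, no measured pair shows this change alone, so the step in this assay must be judged from the neighbouring compounds. A modest move toward a higher number, meaning weaker inhibition of growth, is expected, and it may stay within the scatter. Compound 3 carries no chloro and reads as a limit, > 50000 nM. Compound 2 also carries no chloro, yet compound 2 gives 4470 nM, so the direction remains uncertain.

The expected change is a 1.3-fold higher number from compound 1 to compound 4 (0.13 log units; within the scatter). The estimate for compound 4 is 20000 nM, with an expected range from 6000 nM to 60000 nM.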

Compound 4, concentration for 50% growth inhibition: > 50000 nM
Compound 4: a limit, no number (the forecaster's own chance of this, stated with the estimate: 20%); middle value at least 2.5-fold (0.39 log units) from the limit.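

In this assay compound 4 gives > 50000 nM, which is a limit of the assay and not a number. Hydrogen in place of chloro on an aromatic carbon, ortho to a large group, is now read directly for the first time, as an at least 3.3-fold higher number from compound 1 to compound 4 (0.52 log units; beyond the scatter), so within this pair measurable growth inhibition is lost when 2-chlorophenyl becomes phenyl. The full size of this step cannot be read, and the reading stops at: the limit of > 50000 nM in this assay, at which 2 of the 4 values shown sit.

The compounds shown leave open whether chloro is the only group at this place that keeps a measurable number, or whether fluoro, bromo, methyl, methoxy or an amine would do the same. They also leave open whether the change would read the same way on a core without the benzyloxy group.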